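Hydroxy to methoxy on an inactive salicylanilide pair

This account rests on a few compounds, and the source may have more. Where it says the series, first, only, none or still open, it means among the compounds named here.

Compound 1 `O=C(Nc1ccc(Sc2nc3ccccc3s2)c(Cl)c1)c1cc(Br)ccc1O` carries the larger core. In an assay on isolated protein for inhibition of thiosulfate sulfurtransferase (Homo sapiens), with a stated time of 60 min, in the absence of a further agent (a lower number here means a stronger inhibitor, a higher number a weaker inhibitor), compound 1 gives > 100000 nM, which is a limit of the assay and not a number. Compound 3 `COc1ccc(Br)cc1C(=O)Nc1ccc(Sc2nc3ccccc3s2)c(Cl)c1` differs from it by methyl in place of hydrogen on an oxygen on an aromatic ring. In this assay compound 3 gives > 100000 nM, again a limit. The resulting step is a step that the two limits leave unreadable from compound 1 to compound 3; both ends sit at the limit of > 100000 nM in this assay, at which 3 of the 3 values shown sit, so the size of this change cannot be read here.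

Compound 2 `O=C(Nc1cccc(Cl)c1)c1cc(Br)ccc1O` has a smaller core; the difference between the two cores is not broken down here. In this assay compound 2 gives > 100000 nM, a limit. Compound 4 `COc1ccc(Br)cc1C(=O)Nc1cccc(Cl)c1` differs from compound 2 by methyl in place of hydrogen on an oxygen on an aromatic ring, the same change as from compound 1 to compound 3, at the same kind of place.

Since the measured pair shows only limits, the expected step from compound 2 to compound 4 is set at a step that the limit leaves unreadable from compound 2 to compound 4, resting on compound 2 at > 100000 nM and on the unreadable step from compound 1 to compound 3. Compound 4 is therefore estimated at 150000 nM, most likely reported as a limit, within 100000 nM to 1000000 nM.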

Compound 4, half-maximal inhibitory concentration: > 100000 nM
Compound 4 gave a limit, no number; the forecaster's own chance of this, stated with the estimate: 85%; the middle value lies beyond the limit too.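

No step can be read for hydroxy to methoxy from compound 2 to compound 4, or from compound 1 to compound 3, because in this assay both pairs give only limits of the assay, not numbers: the limit of > 100000 nM in this assay, at which 4 of the 4 values shown sit.

The compounds shown leave open whether this change alters inhibition on either core, since none of them gives a number.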